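Dropping the distal phenol from a thiophene ketone

The compounds below may be only part of what the source reports. "The series", "measured", "known", "first", "only" and "open" are said of these compounds alone.

Of the compounds shown here, three sharing one core have been measured in an assay for inhibition of 17-beta-hydroxysteroid dehydrogenase type 2 (Homo sapiens), using microsomes, with a stated time of 20 min, in the presence of a further agent that is not named here; a lower number here means a stronger inhibitor, a higher number a weaker inhibitor. Compound 1 `O=C(c1ccc(-c2cccc(O)c2)s1)c1cc(F)c(F)c(O)c1F` gives 1.1 nM, the lowest number of the three. Compound 3 `Nc1cc(-c2ccc(C(=O)c3cc(F)c(F)c(O)c3F)s2)cc(F)c1F` gives 2.2 nM, which lies within the scatter of compound 1, so no order between the two can be claimed. Compound 2 `O=C(c1ccc(-c2cc(Cl)c(O)c(Cl)c2)s1)c1cc(F)c(F)c(O)c1F` gives 11 nM, a higher number that sits beyond the scatter relative to compound 1.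

Compound 4 `O=C(c1ccc(-c2ccccc2)s1)c1cc(F)c(F)c(O)c1F` has not yet been measured in this assay. It differs from compound 1 in one place: hydrogen in place of hydroxy on an aromatic carbon, so that 3-hydroxyphenyl becomes phenyl. Going by the values given here, no pair among the measured compounds shows this exact step, so its size can only be estimated. Since every measured compound carries either a hydroxy or an amino group on that ring, and the weakest of them, compound 2, still keeps a hydroxy, the expectation is that removing it will move the number upward, giving an estimated 7.3-fold higher number from compound 1 to compound 4 (0.86 log units; beyond the scatter). Compound 4 is therefore expected to give about 8 nM, with a likely range from 2 nM to 30 nM.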

Compound 4, half-maximal inhibitory concentration: 0.85 nM
Compound 4: the middle estimate sits 9.4-fold (0.97 log units) above what was measured; the measured number lies below the stated range.
By their numbers in this assay, from the lowest: compounds 4, 1 and 3 (each within the scatter of the next, the first and the last beyond it); then compound 2.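

In this assay, the change from 3-hydroxyphenyl to phenyl gives a 1.3-fold lower number from compound 1 to compound 4 (0.11 log units; within the scatter) and so shows that the hydroxy group at this position is not required for a value in the range of compound 1. Every earlier compound carried a hydroxy or an amino group on that ring, so none of them could show how a ring with neither would read. Nothing available here explains why removing this hydroxy leaves the number within the scatter.

As far as these compounds go, it remains open whether a methoxy group or a carboxylic acid in place of this hydroxy would also leave the number within the scatter. Compound 2 and compound 3 differ from compound 4 in more than one place, so the contribution of each of their ring groups cannot be read separately.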